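The source may hold more compounds than are shown below. What is called first, only, known or untested is meant among the compounds shown, and "the series" means these compounds.

In a functional assay on MDA-MB-231 cells (Homo sapiens) for antiproliferative activity, read by MTT assay, with a stated time of 72 h (on this read-out lower numbers stand for stronger inhibition and higher numbers for weaker inhibition), two compounds that share one core have been measured so far. Compound 1 (`O=C(CCc1cccc2c1B(O)OC2)Nc1cccc(I)c1`) gives 5300 nM, and compound 2 (`C#Cc1cccc(NC(=O)CCc2cccc3c2B(O)OC3)c1`) gives 1600 nM, the lower of the two numbers. Compound 3 (`O=C(CCc1cccc2c1B(O)OC2)Nc1cccc(-c2cccc(Cl)c2)c1`) has not yet been measured. It carries 3-chlorophenyl in place of the ethynyl of compound 2 on an aromatic carbon: 3-chlorophenyl in place of ethynyl on an aromatic carbon. For the measured compounds named here, only one measured step bears on this change, the modest swap of iodo for ethynyl, a 3.3-fold lower number from compound 1 to compound 2 (0.52 log units; beyond the scatter). That swap brings in no new ring, so it guides the size of the next step only loosely, and no firm direction follows from it. A small step is expected, leaning towards a higher number and staying within the usual scatter. The expected step is a 1.6-fold higher number from compound 2 to compound 3 (0.19 log units; within the scatter). Compound 3 is estimated at 2500 nM, with a likely range of 700 nM to 9000 nM.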

Compound 3, half-maximal inhibitory concentration: 250 nM
The estimate for compound 3 lay 10-fold (1.00 log units) above the measured number; measured number below the stated range.
By their numbers in this assay, from the lowest: compound 3; then compound 2; then compound 1.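

In this assay, the aromatic carbon meta to a large group accepts a whole extra six-membered aromatic ring: 3-chlorophenyl, with 7 heavy atoms against the 2 of ethynyl, gives a 6.4-fold lower number from compound 2 to compound 3 (0.81 log units; beyond the scatter). Set against iodo, the same group gives a 21-fold lower number from compound 1 to compound 3 (1.33 log units; beyond the scatter), so the earlier swap of iodo for ethynyl had revealed only part of what a change at this position can do. Nothing shown here explains why the number falls when this ring is added.

The compounds shown leave open whether the chlorine contributes to this gain or the ring alone accounts for it, a question that a plain phenyl group at this carbon would address. From the compounds shown here alone, it also remains open how the number would respond to a pyridine ring or a phenyl ring carrying an amine.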